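Trifluoromethylphenyl placement on the shared core

The source may hold more compounds than are shown below. What is called first, only, known or untested is meant among the compounds shown, and "the series" means these compounds.

compound 1 `Oc1ccc(-c2cc(-c3ccccc3F)cc(-c3ccccc3O)n2)cc1`: > 50000 nM
compound 2 `Oc1ccc(-c2cc(-c3ccc(F)cc3)cc(-c3ccccc3O)n2)cc1`: > 50000 nM
compound 3 `Oc1ccc(-c2cc(-c3ccccc3C(F)(F)F)cc(-c3ccccc3O)n2)cc1`: 6690 nM

In a functional assay on DU-145 cells (Homo sapiens) for inhibition (a lower number here means a stronger inhibitor, a higher number a weaker inhibitor), compound 1 gives > 50000 nM, which is a limit of the assay and not a number. Compound 2 likewise gives > 50000 nM, again a limit. For the measured compounds named here, compound 3 gives 6690 nM, the only number in the set; the two other values sit at the limit of > 50000 nM in this assay, at which 2 of the 3 values shown sit. The step that the two limits leave unreadable from compound 1 to compound 2 is therefore unreadable. The steps of an at least 7.4-fold lower number from compound 1 to compound 3 (0.87 log units; beyond the scatter) and an at least 7.4-fold lower number from compound 2 to compound 3 (0.87 log units; beyond the scatter) are at least modest and both run toward stronger inhibition.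

Compound 4 `Oc1ccc(-c2cc(-c3ccc(C(F)(F)F)cc3)cc(-c3ccccc3O)n2)cc1` differs from compound 3 by 4-(trifluoromethyl)phenyl in place of 2-(trifluoromethyl)phenyl on an aromatic carbon. Going by the values given here, no measured step moves a trifluoromethyl group between these two positions on the shared core; the nearest comparison, fluoro in the same two positions on compound 1 and compound 2, lies wholly at the limit and shows no direction. The size of the expected step is thus open, with a weakening more likely than not given that only compound 3 has produced a number.

For compound 4 the expected value in this assay is 15000 nM, estimated between 3000 nM and 50000 nM. This estimate corresponds to an expected 2.2-fold higher number from compound 3 to compound 4 (0.35 log units; beyond the scatter), with a fair chance that only a limit is reported.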

Compound 4, half-maximal inhibitory concentration: > 50000 nM
Compound 4 gave a limit, no number; the forecaster's own chance of this, stated with the estimate: 35%; middle value at least 3.3-fold (0.52 log units) from the limit.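

Placement of the trifluoromethyl group matters at this position on the shared core: 4-(trifluoromethyl)phenyl in place of 2-(trifluoromethyl)phenyl gives an at least 7.4-fold higher number from compound 3 to compound 4 (0.87 log units; beyond the scatter) in this assay. Compound 4 gives > 50000 nM, which is a limit of the assay and not a number. Trifluoromethyl alone is therefore not enough for a readable value here, since only the 2-(trifluoromethyl)phenyl of compound 3 gives a number, and the steps from compound 1 and from compound 2 to compound 4 cannot be read.

How far compound 1, compound 2 and compound 4 differ from one another stays unknown, as all three rest at the same limit: the limit of > 50000 nM in this assay, at which 3 of the 4 values shown sit.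
Also open, as far as these compounds go, is whether a phenyl carrying an amine or a carboxylic acid in place of 2-(trifluoromethyl)phenyl would give a lower number than compound 3.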